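The compounds below may be only part of what the source reports. "The series", "measured", "known", "first", "only" and "open" are said of these compounds alone.

Four nucleoside esters of the same cytosine-bearing core are set side by side here. Compound 1 `CCCCCCCC/C=C/CCCCCCCC(=O)O[C@H]1[C@H](O)[C@H](n2ccc(N)nc2=O)O[C@@H]1CO` is the anchor of the comparison. In a functional assay on HeLa cells (Homo sapiens) for cytotoxicity, read by cell counting, with a stated time of 48 h (a higher number here means that more compound is needed for the effect, a lower number that less compound is needed), compound 1 gives 0.05 ug/mL. Compound 3 `CCCCCCCCCCCCCC(=O)OC[C@H]1O[C@@H](n2ccc(N)nc2=O)[C@@H](O)[C@@H]1OC(=O)CCCCCCCCCCCCC`, with two shorter saturated chains, gives 1.4 ug/mL in this assay, a gap beyond the scatter, so compound 1 stands at the lowest of the two numbers actually measured. Compound 2 `CCCCCCCCCCCCCCCCCCCCCC(=O)OC[C@H]1O[C@@H](n2ccc(N)nc2=O)[C@@H](O)[C@@H]1OC(=O)CCCCCCCCCCCCCCCCCCCCC` reaches only the limit of this assay, where it gives > 10 ug/mL; this is a limit of the measurement and not a number (the limit of > 10 ug/mL in this assay, at which 1 of the 3 values shown sits). Compound 4 `CCCCCCCCCCCCCCCCCC(=O)O[C@H]1[C@H](O)[C@H](n2ccc(N)nc2=O)O[C@@H]1CO` has not yet been measured. It differs from compound 1 in one place: a group of 10 heavy atoms (10 carbon; no ring) in place of a group of 10 heavy atoms (10 carbon; no ring), on a saturated chain carbon, seven bonds along the chain from a carbonyl carbon. Going by the values given here, no pair of measured compounds isolates a change of this kind, so the direction can only be read from the three values shown. Compound 3, which carries saturated chains, sits at the higher 1.4 ug/mL, and that weighs toward a weakening for a saturated chain. A modest rise in the number, by an estimated 4.0-fold higher number from compound 1 to compound 4 (0.60 log units; beyond the scatter), is therefore expected. For compound 4 the expected value in this assay is 0.2 ug/mL, within a range from 0.05 ug/mL to 1 ug/mL.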

Compound 4, concentration for half-maximal effect: 0.13 ug/mL
Compound 4: the middle estimate sits 1.5-fold (0.19 log units) above what was measured, within the range that was stated.
By their numbers in this assay, from the lowest: compound 1; then compound 4; then compound 3. At a limit, above all of these: compound 2.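

In this assay, putting decyl in place of the group of 10 carbon atoms that holds the double bond, on a saturated chain carbon, seven bonds along the chain from a carbonyl carbon, gives a 2.6-fold higher number from compound 1 to compound 4 (0.41 log units; beyond the scatter). Going by these compounds alone, this is the first measured step that isolates a single change in the chain, and it shows that the double bond can be lost at a modest cost, with a step that is nonetheless beyond the usual scatter. Nothing measured here bears on why the number moves.

The compounds shown leave open how a chain with a second double bond, a longer chain or a shorter chain would read at this ester. They also leave open what an amine or a carboxylic acid at the far end of the chain would do.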